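Alkynyl aryl amides: three hydroxylated amides, all at the limit

The source may report more compounds than this note shows. Statements on the series, on what has been measured and on what is new or still open speak of the compounds shown alone.

Measured in a functional assay on HEK293 cells for negative allosteric modulation of metabotropic glutamate receptor 2 (Rattus norvegicus), read by calcium flux, with a stated time of 2.5 min; on this read-out lower numbers stand for stronger inhibition and higher numbers for weaker inhibition:
compound 1, `COc1ccc(C#Cc2ccc(C(=O)N3CCC[C@@H](O)C3)c(F)c2)cc1`, gives > 30000 nM
compound 2, `COc1ccc(C#Cc2ccc(C(=O)N3CC[C@@H](O)C3)cc2)cc1`, gives > 30000 nM
compound 3, `COc1ccc(C#Cc2ccc(C(=O)N3CCC[C@@H](O)C3)cc2F)cc1`, gives > 30000 nM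

Compound 2 stands as a limit of this assay only, not as a number. The other two values shown are likewise limits, so no ordering among compounds 1, 2 and 3 can be read from them; what is seen is the limit of > 30000 nM in this assay, at which 3 of the 3 values shown sit.

Compound 4, `COc1ccc(C#Cc2ccc(C(=O)N3CCCC(OC)C3)cc2)cc1`, is the next variation on the amide. It differs from compound 2 in one place: 3-methoxypiperidin-1-yl in place of 3-hydroxypyrrolidin-1-yl on a carbonyl carbon.

For the measured compounds named here, no step between two measured compounds exists in this assay, so the size of the change is not anchored by data. Given that compound 2 sits at the limit, the expectation for compound 4 is a small shift at most, in no confident direction, and quite possibly another limit. The estimated step from compound 2 to compound 4 in this assay is an at least 1.5-fold lower number from compound 2 to compound 4 (0.17 log units; that floor lies within the scatter). The estimate for compound 4 in this assay is 20000 nM, with a range from 5000 nM to 60000 nM.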

Compound 4, half-maximal inhibitory concentration: > 30000 nM
Compound 4 was reported as a limit (the forecaster's own chance of this, stated with the estimate: 60%); at least 1.5-fold (0.17 log units) between middle value and limit.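

Compound 2 and compound 4 both stand at a limit in this assay, so no step can be read between them. The compounds shown leave open whether any of these amides gives a measurable value, and how they would rank: the limit of > 30000 nM in this assay, at which 4 of the 4 values shown sit.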